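This account rests on a few compounds, and the source may have more. Where it says the series, first, only, none or still open, it means among the compounds named here.

Measured compounds in this series:
compound 1 `CN1CCC(c2ccc3c(c2)oc(=O)n3C(=O)NCCCCc2ccccc2)CC1=O` — 105 nM
compound 2 `CN1CCN(c2ccc3c(c2)oc(=O)n3C(=O)NCCCCc2ccccc2)C(=O)C1` — 52 nM
compound 3 `CCN1CCN(c2ccc3c(c2)oc(=O)n3C(=O)NCCCCc2ccccc2)CC1` — 56 nM

In an assay on HEK293 cells for inhibition of acid ceramidase (Homo sapiens), read by fluorescence, with stated times of 10 min and 3 h (on this read-out higher numbers stand for weaker inhibition and lower numbers for stronger inhibition), compound 3 stands second highest of the three numbers. Its nearest neighbour is compound 2, where a 1.1-fold higher number from compound 2 to compound 3 (0.03 log units; within the scatter) lies within the scatter; its furthest is compound 1, where a 1.9-fold lower number from compound 1 to compound 3 (0.27 log units; within the scatter) is also within the scatter. Among the compounds with values here, only the step from compound 1 to compound 2, a 2.0-fold lower number from compound 1 to compound 2 (0.31 log units; beyond the scatter), reaches beyond it, and the three compounds are otherwise close together.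

Compound 4 `CCN1CCC(c2ccc3c(c2)oc(=O)n3C(=O)NCCCCc2ccccc2)CC1` is the next candidate. The change from compound 3 is 1-ethylpiperidin-4-yl in place of 4-ethylpiperazin-1-yl on an aromatic carbon. Within the data shown here, two measured steps bear on it: a 1.1-fold higher number from compound 2 to compound 3 (0.03 log units; within the scatter) and a 1.9-fold lower number from compound 1 to compound 3 (0.27 log units; within the scatter), both within the scatter. Among the measured compounds shown here, compound 1 is the only measured compound attached through a piperidin-4-yl ring, though that ring carries a methyl and an oxo group rather than an ethyl, so it offers only an indirect comparison. Nothing in the measured set shows a change of the amine ring moving this assay beyond the scatter, so no step beyond it is expected from compound 3 to compound 4, with the number leaning, if anywhere, toward that of compound 1: the expected step is a 1.3-fold higher number from compound 3 to compound 4 (0.13 log units; within the scatter). Compound 4 is estimated at 75 nM, with a likely range of 30 nM to 190 nM.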

Compound 4, half-maximal inhibitory concentration: 92 nM
For compound 4 the middle estimate is 1.2-fold (0.09 log units) below the measured one, and the stated range covers the measured number.
By their numbers in this assay, from the lowest: compounds 2, 3, 4 and 1 (each within the scatter of the next, the first and the last beyond it).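

In this assay, within the data shown here, the exchange of a six-membered non-aromatic ring with 2 hetero atoms for one with 1 hetero atom, with the ethyl group kept, gives the first direct comparison of these two ethyl-bearing rings at this aromatic carbon, and a 1.6-fold higher number from compound 3 to compound 4 (0.22 log units; within the scatter) stays within the scatter. The 1-ethylpiperidin-4-yl group also stays within the scatter of the two oxo-bearing rings, with a 1.8-fold higher number from compound 2 to compound 4 (0.25 log units; within the scatter) and a 1.1-fold lower number from compound 1 to compound 4 (0.06 log units; within the scatter), although compound 1 and compound 2 lie beyond the scatter of each other, so the four compounds form a continuous run with no clear break at this position. Nothing on hand gives a cause for any of these steps.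

Going by these compounds, how far this tolerance extends remains open, for instance to a morpholin-4-yl ring or to a 1-propylpiperidin-4-yl group with its longer chain on the ring nitrogen. Also open, on these data alone, is whether the piperazine and piperidine rings would stay this close with a shorter chain in place of the 4-phenylbutyl chain on the rest of the shared core.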